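Notes on compound 3 in the fused bicyclic aminopyrimidine series

The source may hold more compounds than are shown below. What is called first, only, known or untested is meant among the compounds shown, and "the series" means these compounds.

Measured so far:
compound 1 `NC(=O)C1CCN(c2nc(-c3cccnc3)nc3c2CN(Cc2ccccc2)CC3)CC1`: 100000 nM
compound 2 `CN(C)CCN1CCN(c2nc(-c3cccnc3)nc3c2CN(Cc2ccccc2)CC3)CC1`: 100000 nM

In an assay on cells with Cystic fibrosis transmembrane conductance regulator variant F508del (Homo sapiens) as the target, read by fluorescence, with stated times of 24 h and 30 min (on this read-out lower numbers stand for an effect already at smaller amounts and higher numbers for an effect only at larger amounts of compound), compound 2 gives 100000 nM. Compound 2 stands level with compound 1 at the digits shown: the step of no change at the digits printed from compound 1 to compound 2 (within the scatter) was no change within the scatter, so swapping the group on the aromatic carbon between these two amine-bearing side chains left the read-out where it was.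

Compound 3 `CN1CCN(CCCNc2nc(-c3cccnc3)nc3c2CN(Cc2ccccc2)CC3)CC1` carries the same atoms joined differently: (3-(4-methylpiperazin-1-yl)propyl)amino in place of 4-(2-(dimethylamino)ethyl)piperazin-1-yl on an aromatic carbon. The new group is (3-(4-methylpiperazin-1-yl)propyl)amino on an aromatic carbon of a six-membered aromatic ring with 2 nitrogen, part of a fused or bridged system of two rings, and brings one hydrogen-bond donor where the departing group had none.

For the measured compounds named here, only the step from compound 1 to compound 2 bears on this change, and it was flat. With both measured compounds at the same value, no movement beyond the scatter is expected for compound 3; the expected step is no change at the digits printed from compound 2 to compound 3 (within the scatter). Compound 3 is therefore estimated at 100000 nM, with a range from 25000 nM to 100000 nM.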

Compound 3, half-maximal effective concentration: 100000 nM
Compound 3: middle estimate and measured number agree at the digits printed; the measured number falls inside the stated range.
By their numbers in this assay, from the lowest: compounds 1, 2 and 3 (each within the scatter of the next).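

In this assay the read-out shows no change at the digits printed from compound 2 to compound 3 (within the scatter) when the same atoms are joined differently on the aromatic carbon, so this rearrangement, with (3-(4-methylpiperazin-1-yl)propyl)amino entering with 1 hydrogen-bond donor and 4-(2-(dimethylamino)ethyl)piperazin-1-yl leaving with 0, does not separate the two compounds. The comparison with the amide-bearing side chain gives no change at the digits printed from compound 1 to compound 3 (within the scatter) on the same carbon, so 4-carbamoylpiperidin-1-yl and (3-(4-methylpiperazin-1-yl)propyl)amino also cannot be told apart here. Among these three groups, neither the added hydrogen-bond donor nor the different connection of the atoms registers in this assay, and no further measurement accounts for this flat result.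

On these data alone, it remains open whether any group at this aromatic carbon can move the read-out, for example a carboxylic acid, a morpholin-4-yl ring or a short primary amine chain. The three compounds also share the benzyl and pyridin-3-yl groups, so they say nothing about replacing either one, for instance the benzyl with a methyl or the pyridin-3-yl with a phenyl.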